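The source may hold more compounds than are shown below. What is called first, only, known or untested is meant among the compounds shown, and "the series" means these compounds.

Measured compounds:
compound 1, `Cc1ccc(C(=O)NCN2CCC(c3cccc[n+]3[O-])CC2)cc1C` — 38 nM
compound 2, `O=C(NCN1CCC(c2cccc[n+]2[O-])CC1)c1cnccc1Cl` — 1290 nM
compound 3, `O=C(NCN1CCC(c2cccc[n+]2[O-])CC1)c1ccccc1` — 532 nM

The three compounds share one core and differ only in the group on the carbonyl carbon. In a functional assay on HEK293 cells for agonist activity at D(4) dopamine receptor (Homo sapiens), read by FLIPR (on this read-out lower numbers stand for an effect already at smaller amounts and higher numbers for an effect only at larger amounts of compound), compound 1 gives 38 nM, the lowest of the three numbers. Compound 3 gives 532 nM and compound 2 gives 1290 nM. The steps are large: a 14-fold higher number from compound 1 to compound 3 (1.15 log units; beyond the scatter) and a 34-fold higher number from compound 1 to compound 2 (1.53 log units; beyond the scatter), while the step between the two weaker compounds is smaller, a 2.4-fold lower number from compound 2 to compound 3 (0.38 log units; beyond the scatter).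

Compound 4, `Cc1ccc(C(=O)NCN2CCC(c3cccc[n+]3[O-])CC2)cc1C(F)(F)F`, has not yet been measured in this assay. It differs from compound 1 in one place: trifluoromethyl in place of methyl on an aromatic carbon. For the measured compounds named here, no measured step tests such an exchange of a single substituent; both steps away from compound 1 replace the whole group on the carbonyl carbon and move the number far upward. The new change keeps the 3,4-disubstituted pattern of compound 1, so a step of modest size is expected, a 2.1-fold higher number from compound 1 to compound 4 (0.32 log units; beyond the scatter), most likely toward a somewhat higher number. Compound 4 is therefore estimated at 80 nM, with a range from 25 nM to 300 nM.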

Compound 4, half-maximal effective concentration: 85 nM
For compound 4 the middle estimate is 1.1-fold (0.03 log units) below the measured one; the measured number falls inside the stated range.
By their numbers in this assay, from the lowest: compound 1; then compound 4; then compound 3; then compound 2.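

In this assay the exchange of methyl for trifluoromethyl, on an aromatic carbon ortho to a methyl group and meta to a large group, gives a 2.2-fold higher number from compound 1 to compound 4 (0.35 log units; beyond the scatter). For the compounds shown here, this is the first look at a single substituent on this aromatic ring, and the place accepts a group of 4 heavy atoms in place of 1 heavy atom with a far smaller step than replacing the whole group on the carbonyl carbon, as in a 14-fold higher number from compound 1 to compound 3 (1.15 log units; beyond the scatter). No measured evidence on the cause of this step is at hand.

The compounds shown leave open how a chlorine atom, a methoxy group or a nitrile would fare at this same place. They also leave open whether trifluoromethyl would give a step of similar size on the phenyl group of compound 3.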